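Swapping a nitro for a methyl on the aromatic nitrogen's phenyl

The compounds below may be only part of what the source reports. "The series", "measured", "known", "first", "only" and "open" are said of these compounds alone.

Three compounds share one core and differ only in the aryl group on the aromatic nitrogen. Compound 1 `Cc1cc2occ(-c3nc(-c4ccccc4)c(-c4ccccc4)n3-c3ccccc3Cl)c(=O)c2cc1Cl` gives 6250 nM in a functional assay on HepG2 cells (Homo sapiens) for inhibition, read by MTT assay, with a stated time of 72 h; a higher number here means a weaker inhibitor, a lower number a stronger inhibitor. Compound 2 `COc1ccccc1-n1c(-c2coc3cc(C)c(Cl)cc3c2=O)nc(-c2ccccc2)c1-c1ccccc1` gives 12500 nM, and compound 3 `Cc1cc2occ(-c3nc(-c4ccccc4)c(-c4ccccc4)n3-c3cccc([N+](=O)[O-])c3)c(=O)c2cc1Cl` gives 25000 nM. Compound 3 thus has the highest number of the three, although its gap to compound 2 is within the scatter; only a 4.0-fold higher number from compound 1 to compound 3 (0.60 log units; beyond the scatter) is beyond it.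

Compound 4 `Cc1cccc(-n2c(-c3coc4cc(C)c(Cl)cc4c3=O)nc(-c3ccccc3)c2-c2ccccc2)c1` differs from compound 3 in one place: methyl in place of nitro on an aromatic carbon. Among the compounds with values here, no measured step removes a nitro group directly, so the only guide is that the two compounds without it sit at lower numbers: a 4.0-fold higher number from compound 1 to compound 3 (0.60 log units; beyond the scatter) and a 2.0-fold higher number from compound 2 to compound 3 (0.30 log units; within the scatter). Both point the same way, one of them modestly and one within the scatter, so a modest fall in the number is expected, with the estimate for the step being a 2.5-fold lower number from compound 3 to compound 4 (0.40 log units; beyond the scatter). Compound 4 is therefore expected to give about 10000 nM, likely between 4000 nM and 25000 nM.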

Compound 4, half-maximal inhibitory concentration: 6250 nM
The estimate for compound 4 lay 1.6-fold (0.20 log units) above the measured number, and the stated range covers the measured number.
By their numbers in this assay, from the lowest: compounds 1, 4, 2 and 3 (each within the scatter of the next, the first and the last beyond it).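

Replacing the nitro directly with methyl at this position gives a 4.0-fold lower number from compound 3 to compound 4 (0.60 log units; beyond the scatter) in this assay, so this change now has a direct reading instead of an inference from compounds that also differ in where the group sits. Compound 4 also matches the 2-chlorophenyl compound, with no change at the digits printed from compound 1 to compound 4 (within the scatter), and a 2.0-fold lower number from compound 2 to compound 4 (0.30 log units; within the scatter) is within the scatter, so compound 3 stands apart from compound 1 and compound 4 but not from compound 2. Nothing shown gives a reason for the step caused by this swap.

From the compounds shown here alone, compound 1 and compound 2 carry their groups at a different place on the phenyl from compound 3 and compound 4, so it remains open how chloro or methoxy would behave where the nitro and methyl sit. Going by these compounds, an amine or a carboxylic acid at that place also remains open.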